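Replacing the methoxyphenyl amide of compound 3 with a methylphenyl

The source may report more compounds than this note shows. Statements on the series, on what has been measured and on what is new or still open speak of the compounds shown alone.

Three amides sharing one core were tested in an ADME assay on HepG2 2.2.15 cells (Homo sapiens) for cytotoxicity, read by MTT assay, with stated times of 48 h and 9 days; on this read-out higher numbers stand for lower toxicity in this test and lower numbers for higher toxicity in this test. Compound 1 `COc1ccc2c(=O)c(/C=C/C(=O)Nc3cccc(Cl)c3)coc2c1` gives 1100000 nM in this assay, compound 2 `COc1ccc2c(=O)c(/C=C/C(=O)NCc3ccccc3F)coc2c1` gives 146000 nM, and compound 3 `COc1ccc(NC(=O)/C=C/c2coc3cc(OC)ccc3c2=O)cc1` gives 718000 nM. Compound 3 thus stands second highest of the three numbers, close to compound 1 and well apart from compound 2. The step of a 1.5-fold lower number from compound 1 to compound 3 (0.19 log units; within the scatter) lies within the scatter, while the step of a 4.9-fold higher number from compound 2 to compound 3 (0.69 log units; beyond the scatter) and the step of a 7.5-fold lower number from compound 1 to compound 2 (0.88 log units; beyond the scatter) are beyond it.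

Compound 4 `COc1ccc2c(=O)c(/C=C/C(=O)Nc3ccccc3C)coc2c1` is obtained from compound 3 by 2-methylphenyl in place of 4-methoxyphenyl on an amide-type nitrogen. Going by the values given here, the step that bears most directly on this change is the one from compound 1 to compound 3, where exchanging one substituted phenyl for another on the amide-type nitrogen left the number within the scatter. The account therefore expects no step beyond the scatter for compound 4, which is estimated at 800000 nM, with a range from 300000 nM to 2000000 nM, corresponding to an expected step of a 1.1-fold higher number from compound 3 to compound 4 (0.05 log units; within the scatter).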

Compound 4, half-maximal cytotoxic concentration: 59700 nM
Beside the measured number, compound 4's estimate is 13-fold (1.13 log units) above it; measured number below the stated range.
By their numbers in this assay, from the lowest: compound 4; then compound 2; then compounds 3 and 1 (each within the scatter of the next).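

In this assay, the earlier swap of one substituted phenyl for another had stayed within the scatter, so the aryl group on the amide-type nitrogen looked tolerant of change, yet this exchange gives a 12-fold lower number from compound 3 to compound 4 (1.08 log units; beyond the scatter). The 2-methylphenyl amide also falls past the 2-fluorobenzyl amide, with a 2.4-fold lower number from compound 2 to compound 4 (0.39 log units; beyond the scatter), and past the 3-chlorophenyl amide, with an 18-fold lower number from compound 1 to compound 4 (1.27 log units; beyond the scatter), so among these four amides, the aryl groups alone do not set a narrow range, and compound 4 is the most toxic in this test. Nothing given here accounts for this drop.

The compounds shown leave apart the group and its place on the ring, as the methyl and the methoxy differ in both. A 4-methylphenyl or a 2-methoxyphenyl on the same nitrogen would separate the two.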